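Working notes: from compound 3 to compound 4

The compounds below may be only part of what the source reports. "The series", "measured", "known", "first", "only" and "open" are said of these compounds alone.

Values in an ADME assay on L02 cells (Homo sapiens) for cytotoxicity, read by MTT assay (on this read-out lower numbers stand for stronger inhibition and higher numbers for weaker inhibition), as measured so far:
compound 1 `COc1ccc(/C=C/C(=O)c2ccc(OC)c3c2OC(C)(C)C=C3)cc1OCC=C(C)C` gives > 10000 nM
compound 2 `C=CCOc1cc(/C=C/C(=O)c2ccc(OC)c3c2OC(C)(C)C=C3)ccc1OC` gives > 20000 nM
compound 3 `COc1ccc(/C=C/C(=O)c2ccc(OC)c3c2OC(C)(C)C=C3)cc1OC(=O)C(C)C` gives > 10000 nM

Compound 3 stands at > 10000 nM in this assay and that figure is a limit, not a number. The series offers no exact value, only the limit of > 10000 nM in this assay, at which 2 of the 3 values shown sit, and the limit of > 20000 nM in this assay, at which 1 of the 3 values shown sits, as its readings.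

Compound 4 `COc1ccc(/C=C/C(=O)Oc2cc(/C=C/C(=O)c3ccc(OC)c4c3OC(C)(C)C=C4)ccc2OC)cc1` differs from compound 3 as follows: 2-(4-methoxyphenyl)ethenyl in place of isopropyl on a carbonyl carbon and so carries 2-(4-methoxyphenyl)ethenyl in place of isopropyl on a carbonyl carbon.

The measured steps that bear on this are a step that the two limits leave unreadable from compound 1 to compound 3 and a step that the two limits leave unreadable from compound 2 to compound 3 and also a step that the two limits leave unreadable from compound 1 to compound 2 in the same series. None of them has a size to carry over, so no direction of change can be drawn from them. Compound 4 is expected to be reported as a limit too. What is expected is a step that the limit leaves unreadable from compound 3 to compound 4 and no firmer claim. For compound 4 the estimate is 20000 nM as an expected value, with an expected range from 8000 nM to 50000 nM around it.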

Compound 4, half-maximal inhibitory concentration: 18000 nM
Compound 4: the middle estimate sits 1.1-fold (0.05 log units) above what was measured; the range from low to high includes it.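

Within the data shown here, compound 4, with (2-(4-methoxyphenyl)ethenyl)carbonyl on the oxygen on the aromatic ring, gives the first reading in this assay that is a number and not a limit. Among these compounds, the only step that can be read is an at least 1.1-fold lower number from compound 2 to compound 4 (0.04 log units; that floor lies within the scatter), so it establishes no change at this position. The steps to compound 4 from compound 1 and from compound 3 cannot be read, and the other readings remain limits: the limit of > 10000 nM in this assay, at which 2 of the 4 values shown sit.

Compound 3 stands only at the limit > 10000 nM, which leaves open how 2-(4-methoxyphenyl)ethenyl compares with isopropyl on the carbonyl carbon. Also open, on these data alone, is how this assay would read with a longer chain or a group carrying an amine on that carbonyl carbon.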